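Compound 1 to Compound 4: Expected Liver Microsome Stability

This account rests on a few compounds, and the source may have more. Where it says the series, first, only, none or still open, it means among the compounds named here.

Measured compounds:
Compound 1, `CC[C@]1(C(=O)O)CC[C@H](C(=O)N2CC[C@](c3ccc(C(F)(C(F)(F)F)C(F)(F)F)cc3)(S(=O)(=O)c3ccc(F)cc3)C2)CC1`, in an ADME assay on microsomes from liver (Mus musculus) for metabolic stability, with a stated time of 10 min (a lower number here means that less of the compound is left, a higher number that more of the compound is left), compound 1 shows "not determined" (no result reported).
Compound 2, `O=C([C@H]1CC[C@H](CO)CC1)N1CC[C@](c2ccc(C(F)(C(F)(F)F)C(F)(F)F)cc2)(S(=O)(=O)c2ccc(F)cc2)C1`, in this assay compound 2 gives 63%.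
Compound 3, `O=C(C1CCS(=O)(=O)C1)N1CC[C@](c2ccc(C(F)(C(F)(F)F)C(F)(F)F)cc2)(S(=O)(=O)c2ccc(F)cc2)C1`, in this assay compound 3 gives 78%; 96% (2 entries).

Compound 1 therefore has no number of its own in this assay; only a further entry without a number exists for it. Its place among the others cannot be set from what was measured. Compound 4, `O=C(C1CCS(=O)(=O)CC1)N1CC[C@](c2ccc(C(F)(C(F)(F)F)C(F)(F)F)cc2)(S(=O)(=O)c2ccc(F)cc2)C1`, has not yet been measured in this assay. It differs from compound 1 in one place: 1,1-dioxothian-4-yl in place of 4-carboxy-4-ethylcyclohexyl on a carbonyl carbon. The group that enters is a close relative of the ring carried by compound 3, which has one more carbon in its ring than compound 3.

With no number for compound 1, no size or direction can be given for the step to compound 4; what can be said comes from the neighbours. Compound 2 and compound 3 both keep well over half of the compound, and the two entries of compound 3 the several entries of compound 3 in this assay, 78%; 96% (2 entries) show how widely repeats of one compound can sit. Compound 4 is expected to land near compound 3. For compound 4 the estimated value in this assay is 82%, within a range from 58% to 100%.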

Compound 4, percent of the compound remaining: 96%
For compound 4 the middle estimate is 14 percentage points below the measured one, within the range that was stated.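

On a carbonyl carbon whose other neighbour is an amide-type nitrogen in a ring, the group can change the result in this assay substantially: replacing 4-(hydroxymethyl)cyclohexyl with 1,1-dioxothian-4-yl gives a number 33 percentage points higher from compound 2 to compound 4 (beyond the scatter). The earlier compounds shown here also did not show whether the ring of compound 3 could carry one more carbon and still leave a high share of the compound intact, and compound 4 now does so at 96%, a value that matches the upper entry of compound 3. That single entry for compound 4 needs some caution, as repeat entries for one compound can sit far apart: the several entries of compound 3 in this assay, 78%; 96% (2 entries)

The step from compound 1 cannot be read, so the compounds shown do not tell how the 4-carboxy-4-ethylcyclohexyl group compares with 1,1-dioxothian-4-yl in this read-out. Going by these compounds, it also remains open whether the sulfur and its two oxygens are needed for the high value, or whether a six-membered ring with an amine or a plain ether oxygen at that ring position would leave as much of the compound intact.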